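The source may hold more compounds than are shown below. What is called first, only, known or untested is meant among the compounds shown, and "the series" means these compounds.

Three compounds built around a benzimidazole-type sulfoxide were measured in a physicochemical assay for acid dissociation. Compound 1, `COc1cnc(C[S+]([O-])c2nc3cc(OCC(F)(F)F)ccc3[nH]2)c(C)c1OC`, gives 3.72. Compound 2, `COc1ccnc(C[S+]([O-])c2nc3cc(OCC(F)(F)F)ccc3[nH]2)c1C`, gives 4.97. The change between them is hydrogen in place of methoxy on an aromatic carbon, and it produced a number 1.25 log units higher from compound 1 to compound 2 (beyond the scatter). Compound 3, `COc1ccnc(C[S+]([O-])c2nc3cc(OC(F)(F)C(F)F)ccc3[nH]2)c1OC`, gives 3.86; the difference between its core and the core of compound 1 is not broken down here. Compound 4, `COc1ccnc(C[S+]([O-])c2nc3cc(OC(F)(F)C(F)F)ccc3[nH]2)c1`, has not yet been measured. Within the data shown here, it arises from compound 3 by hydrogen in place of methoxy on an aromatic carbon, the same kind of change as the one from compound 1 to compound 2, though the surroundings are not identical: in compound 1 the leaving methoxy sat ortho to a methoxy group, meta to a methyl group and para to a large group, whereas in compound 3 it sits ortho to a large group and ortho to a methoxy group, each two atoms from the ring nitrogen. Given that the earlier step gave a number 1.25 log units higher from compound 1 to compound 2 (beyond the scatter), a step of similar size is expected, a number 1.09 log units higher from compound 3 to compound 4 (beyond the scatter), so that compound 4 in this assay is estimated at 4.95, between 4.45 and 5.45.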

Compound 4, acid dissociation constant: 4.25
Compound 4: middle estimate off by 0.70 log units, on the high side; the whole stated range lies above it.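

In this assay, hydrogen in place of methoxy on an aromatic carbon gives a number 0.39 log units higher from compound 3 to compound 4 (beyond the scatter), against a number 1.25 log units higher from compound 1 to compound 2 (beyond the scatter), so on these two cores the number moves the same way, but the size of the step does not carry over. Among these compounds, with only two such pairs, this shows that a step measured on one core was no reliable guide to its size on the other, but it does not show how the step would behave across the series, and the two cores differ in more than one place, so no single difference between them can be tied to the smaller step. Nothing available here explains why the two steps differ in size.

The compounds shown leave open how an amine or a chlorine on that aromatic carbon, two atoms from the ring nitrogen, would compare with hydrogen and methoxy. They also leave open whether a longer chain such as ethoxy at the same place would give a step nearer the larger or the smaller one.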